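Ring swap on the shared core and its expected toxicity

The source may report more compounds than this note shows. Statements on the series, on what has been measured and on what is new or still open speak of the compounds shown alone.

Compound 2, `COc1nc(-c2cnsc2)ccc1[C@@H](c1ccccc1)[C@@](O)(CCN(C)C)c1cccc2ccccc12`, is the only one of the three measured compounds with a numerical result in a toxicity assay on Vero cells (Chlorocebus sabaeus) for cytotoxicity; on this read-out lower numbers stand for higher toxicity in this test and higher numbers for lower toxicity in this test: compound 2 gives 26.3 ug/mL. Compound 1, `COc1ncc(-c2ccccc2)cc1[C@@H](c1ccccc1)[C@@](O)(CCN(C)C)c1ccccc1`, reaches only a limit of this assay, > 50 ug/mL. Compound 3, `COc1nc(-c2ccc(OC(F)(F)F)cc2)ccc1[C@@H](c1ccccc1)[C@@](O)(CCN(C)C)c1cccc2ccccc12`, likewise stops at a limit, > 50 ug/mL. The step of an at least 1.9-fold higher number from compound 2 to compound 3 (0.27 log units; that floor lies within the scatter) is thus known only as a floor, and that floor lies within the scatter. Compound 4, `COc1nc(-c2ccccc2Cl)ccc1[C@@H](c1ccccc1)[C@@](O)(CCN(C)C)c1cccc2ccccc12`, differs from compound 2 by 2-chlorophenyl in place of 1,2-thiazol-4-yl on an aromatic carbon. Among the measured compounds shown here, that change resembles the one from compound 2 to compound 3, since in both a six-membered aromatic ring of carbon only replaces the five-membered aromatic ring with 2 hetero atoms at the same place, and that single step is the only measured one bearing on it; it pointed toward lower toxicity, and the limit of > 50 ug/mL in this assay, at which 2 of the 3 values shown sit, shows where two of the three results sit. Compound 4 is therefore expected to move the same way, by a 1.7-fold higher number from compound 2 to compound 4 (0.23 log units; within the scatter), possibly again reaching only a limit. The estimate for compound 4 is 45 ug/mL, between 20 ug/mL and 100 ug/mL.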

Compound 4, half-maximal cytotoxic concentration: > 50 ug/mL
Compound 4: a limit, no number; the forecaster's own chance of this, stated with the estimate: 50%; middle value at least 1.1-fold (0.04 log units) from the limit.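

In this assay compound 4 gives > 50 ug/mL, which is a limit and not a number. The step is an at least 1.9-fold higher number from compound 2 to compound 4 (0.27 log units; that floor lies within the scatter), so a second six-membered aromatic ring of carbon only, here 2-chlorophenyl with its substituent on the ring, now stands in place of 1,2-thiazol-4-yl next to the ring nitrogen, and again the size of the step is known only as a floor that does not pass the scatter. The step from compound 3 to compound 4 cannot be read, and the readings at this position now gather at one end of the assay: the limit of > 50 ug/mL in this assay, at which 3 of the 4 values shown sit.

Going by these compounds, how far the true values of compound 3 and compound 4 lie from that of compound 2 remains open. Also open, on these data alone, is how a pyridinyl ring, an amine or a carboxylic acid at this place would read.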